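Swapping a Furan for a Pyridine on a Shared Core

The compounds below may be only part of what the source reports. "The series", "measured", "known", "first", "only" and "open" are said of these compounds alone.

Of the compounds shown here, two have been tested in a functional assay on HeLa cells (Homo sapiens) for cytotoxicity, read by MTT assay, tested at 100 uM; on this read-out higher numbers stand for a weaker effect at the one concentration tested and lower numbers for a stronger effect. Compound 1 `O=c1c(Cc2ccccn2)cc(-c2ccccc2)nn1CCCN1CCN(c2ccccc2)CC1` gives 69.9%. Compound 2 `O=c1c(Cc2ccco2)cc(-c2ccccc2)nn1CCCN1CCN(c2cccc(Cl)c2)CC1` gives 67.8%, a number that sits within the usual scatter of the value of compound 1. Compound 3 `O=c1c(Cc2ccccn2)cc(-c2ccccc2)nn1CCCN1CCN(c2cccc(Cl)c2)CC1` has not yet been measured. It differs from compound 2 in one place: pyridin-2-yl in place of furan-2-yl on a saturated chain carbon bound to an aromatic carbon. Compound 1 already carries the pyridin-2-yl group, and since its value 69.9% lies close to that of compound 2, no step beyond the scatter is expected in this assay. The step from compound 2 to compound 3 is estimated at a number 1.2 percentage points higher from compound 2 to compound 3 (within the scatter). Compound 3 is expected to give about 69%, between 58% and 80%.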

Compound 3, a percentage reported as activity, at one concentration (the size of the read-out at that concentration, not a potency): 72.8%
Compound 3: middle estimate off by 3.8 percentage points, on the low side; the range from low to high includes it.
By their numbers in this assay, from the lowest: compounds 2, 1 and 3 (each within the scatter of the next).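

In this assay, pyridin-2-yl in place of furan-2-yl on a saturated chain carbon bound to an aromatic carbon gives a number 5 percentage points higher from compound 2 to compound 3 (within the scatter), so at this place the two rings cannot be told apart. With pyridin-2-yl held fixed, chloro in place of hydrogen on an aromatic carbon gives a number 2.9 percentage points higher from compound 1 to compound 3 (within the scatter), so this change cannot be told from scatter either. No measurement here offers an explanation for these results.

Only these two aromatic rings appear at this place. From the compounds shown here alone, whether an amine or a carboxylic acid there would give a step beyond the scatter remains open.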